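A Sulfamoylphenyl Variant in an Inactive Spirocyclic Series

The source may report more compounds than this note shows. Statements on the series, on what has been measured and on what is new or still open speak of the compounds shown alone.

Compound 3 `CC(=O)Nc1ccc(-n2nncc2CN2C(=O)C3(C(C#N)=C(N)Oc4c3c3nc5ccccc5nc3c3ccccc43)c3ccccc32)cc1` stands among three close analogues that share one core and differ only in the aryl group on an aromatic nitrogen. In a functional assay on MCF7 cells (Homo sapiens) for antiproliferative activity, read by MTT assay, with a stated time of 48 h (a higher number here means a weaker inhibitor, a lower number a stronger inhibitor), compound 3 gives only a limit, > 50000 nM. Compound 1 `N#CC1=C(N)Oc2c(c3nc4ccccc4nc3c3ccccc23)C12C(=O)N(Cc1cnnn1-c1ccc(F)cc1)c1ccccc12` likewise gives only a limit in this assay, > 50000 nM. Compound 2 `CCOc1ccccc1-n1nncc1CN1C(=O)C2(C(C#N)=C(N)Oc3c2c2nc4ccccc4nc2c2ccccc32)c2ccccc21` also gives only a limit, > 50000 nM. All three values thus sit at the limit of > 50000 nM in this assay, at which 3 of the 3 values shown sit, so the steps a step that the two limits leave unreadable from compound 1 to compound 2, a step that the two limits leave unreadable from compound 1 to compound 3 and a step that the two limits leave unreadable from compound 2 to compound 3 cannot be read in size or direction.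

Compound 4 `N#CC1=C(N)Oc2c(c3nc4ccccc4nc3c3ccccc23)C12C(=O)N(Cc1cnnn1-c1cccc(S(N)(=O)=O)c1)c1ccccc12` differs from compound 3 by 3-sulfamoylphenyl in place of 4-acetamidophenyl on an aromatic nitrogen. The measured steps that bear on this change are exactly those three exchanges of the aryl group on the aromatic nitrogen, and each of them is unreadable between two limits. Going by the values given here, there is therefore no measured step from which a gain or loss could be expected; compound 4 is expected to stay at the limit as well. Compound 4 is estimated at 60000 nM, with a range from 30000 nM to 200000 nM. The expected step that the limit leaves unreadable from compound 3 to compound 4 is accordingly none beyond the scatter.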

Compound 4, half-maximal inhibitory concentration: 42500 nM
Beside the measured number, compound 4's estimate is 1.4-fold (0.15 log units) above it; the measured number falls inside the stated range.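

In this assay, going by these compounds alone, compound 4 is the only one of the four compounds to give a number rather than a limit, so a change of the aryl group on this aromatic nitrogen can now be given a floor, though not a size: the limit of > 50000 nM in this assay, at which 3 of the 4 values shown sit. The three new steps are an at least 1.1-fold lower number from compound 3 to compound 4 (0.07 log units; that floor lies within the scatter), an at least 1.1-fold lower number from compound 2 to compound 4 (0.07 log units; that floor lies within the scatter) and an at least 1.1-fold lower number from compound 1 to compound 4 (0.07 log units; that floor lies within the scatter); each is only a floor, so 3-sulfamoylphenyl cannot be said to differ from the other three aryl groups. The steps among compound 1, compound 2 and compound 3 still cannot be read.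

On these data alone, what 4-sulfamoylphenyl would give on this nitrogen remains open. So does whether a carboxylic acid or an amine on that phenyl ring would bring a value clearly away from this level.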